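The source may hold more compounds than are shown below. What is called first, only, known or untested is meant among the compounds shown, and "the series" means these compounds.

Working notes on the series. Among the measured compounds shown here, in a functional assay on MDA-MB-231 cells (Homo sapiens) for inhibition, read by sulforhodamine B assay, with a stated time of 48 h (a lower number here means a stronger inhibitor of growth, a higher number a weaker inhibitor of growth), compound 2 `CCCCNc1nc(N2CC(=O)Nc3cc(OC)ccc32)c2ccccc2n1` stands at the low end of the two numbers so far, with 7.19 nM, while compound 1 `COc1ccc2c(c1)NC(=O)CN2c1nc(Nc2cccc(C#N)c2)nc2ccccc12` gives 97.1 nM. For the measured compounds named here, the one measured step between them, a 14-fold lower number from compound 1 to compound 2 (1.13 log units; beyond the scatter), came from putting butyl in place of 3-cyanophenyl on the nitrogen on the aromatic ring.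

Compound 3 `COc1ccc2c(c1)NC(=O)CN2c1nc(NC2CCCC2)nc2ccccc12` is next to be tested there. (cyclopentyl in place of butyl on a nitrogen on an aromatic ring). The measured step replaced an aromatic group with a chain, so it bears only loosely on exchanging one alkyl group for another at the same nitrogen; it shows that an alkyl group at this position is tolerated, nothing more. Going by the values given here, no step between two alkyl groups has been measured. The expectation is therefore a step of a 1.0-fold lower number from compound 2 to compound 3 (0.01 log units; within the scatter), within the scatter. Compound 3 is estimated at 7 nM, with a range from 2.5 nM to 20 nM.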

Compound 3, concentration for 50% growth inhibition in the MDA-MB-231 assay: 17.6 nM
Compound 3: the middle estimate sits 2.5-fold (0.40 log units) below what was measured; low and high end bracket the measured number.
By their numbers in the MDA-MB-231 assay, from the lowest: compound 2; then compound 3; then compound 1.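

Among the compounds shown here, in the MDA-MB-231 assay, the first measured exchange of one alkyl group for another at this nitrogen gives a 2.4-fold higher number from compound 2 to compound 3 (0.39 log units; beyond the scatter), so the position distinguishes between alkyl groups, while cyclopentyl still keeps a clear gain over the aromatic group, with a 5.5-fold lower number from compound 1 to compound 3 (0.74 log units; beyond the scatter). In a physicochemical assay for solubility, read by HPLC, at pH 7.4 (on this read-out lower numbers stand for lower solubility and higher numbers for higher solubility), compound 2 gives 1.34 ug/mL and compound 3 gives 1.45 ug/mL, with a 1.1-fold higher number from compound 2 to compound 3 (0.03 log units; within the scatter), so the change that separates the two in the MDA-MB-231 assay does not separate them on this read-out. Nothing available explains the step from butyl to cyclopentyl.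

From the compounds shown here alone, whether a longer chain or a cyclohexyl group at this nitrogen would match butyl in the MDA-MB-231 assay remains open. Also open, going by these compounds, is how an amine or a carboxylic acid at the end of the chain would read in the physicochemical assay.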